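Replacing the amino group of compound 2 with hydrogen

This account rests on a few compounds, and the source may have more. Where it says the series, first, only, none or still open, it means among the compounds named here.

In a functional assay on SW480 cells (Homo sapiens) for antiproliferative activity, read by MTT assay, with a stated time of 48 h (a higher number here means a weaker inhibitor, a lower number a stronger inhibitor), compound 1 (`CCCCC(CCO)n1cnc2c(OC)ncnc21`) gives > 50000 nM, which is a limit of the assay and not a number. Compound 2 (`CCCCC(CCO)n1cnc2c(N)ncnc21`) gives > 50000 nM, also a limit and not a number. Compound 2 therefore has no measured number and stands with compound 1 at the same limit: the limit of > 50000 nM in this assay, at which 2 of the 2 values shown sit.

Compound 3 (`CCCCC(CCO)n1cnc2cncnc21`) has hydrogen in place of amino on an aromatic carbon.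

Among the compounds with values here, the only measured step bearing on this change is a step that the two limits leave unreadable from compound 1 to compound 2, which has amino in place of methoxy on an aromatic carbon. Its size cannot be read, so it indicates no direction. No step beyond the scatter is therefore expected in this assay, and a further limit is the likeliest report. The expected step is a step that the limit leaves unreadable from compound 2 to compound 3. For compound 3 the estimate is 60000 nM, with an expected range of 25000 nM to 120000 nM.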

Compound 3, half-maximal inhibitory concentration: > 50000 nM
Compound 3 gave a limit, no number; the forecaster's own chance of this, stated with the estimate: 85%; the middle value is on the limit's open side.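

No step can be read among compound 1, compound 2 and compound 3, since all three give a limit and not a number: the limit of > 50000 nM in this assay, at which 3 of the 3 values shown sit.

Still open is how hydrogen, amino and methoxy on this aromatic carbon compare, as none of the compounds shown gives a number.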